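The compounds below may be only part of what the source reports. "The series", "measured", "known", "first", "only" and "open" are said of these compounds alone.

Working notes on the series, nitrogen substituent. In a functional assay on HeLa cells (Homo sapiens) for antiproliferative activity, read by MTT assay, with a stated time of 72 h (on this read-out lower numbers stand for stronger inhibition and higher numbers for weaker inhibition), compound 1 `O=C1COc2ccc(-c3cccc(NS(=O)(=O)c4ccc(F)cc4)c3)cc2N1c1ccc(Cl)cc1` gives 35000 nM and compound 2 `O=C1COc2ccc(-c3cccc(NS(=O)(=O)c4ccc(F)cc4)c3)cc2N1c1ccccc1` gives 17700 nM, and the step of a 2.0-fold lower number from compound 1 to compound 2 (0.30 log units; within the scatter) separates them. Compound 3 `O=C1COc2ccc(-c3cccc(NS(=O)(=O)c4ccc(F)cc4)c3)cc2N1C1CC1` gives > 40000 nM, which is a limit of the assay and not a number.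

Two measured steps lead to that limit: an at least 2.2-fold higher number from compound 2 to compound 3 (0.35 log units; beyond the scatter) and an at least 1.1-fold higher number from compound 1 to compound 3 (0.05 log units; that floor lies within the scatter). Only the first is beyond the scatter, and both are floors.

Compound 4 `O=C1COc2ccc(-c3cccc(NS(=O)(=O)c4ccc(F)cc4)c3)cc2N1C1CCCCC1` differs from compound 3 by cyclohexyl in place of cyclopropyl on an amide-type nitrogen in a ring. For the measured compounds named here, no measured step covers this exchange directly. The nearest guide is compound 2, with an at least 2.2-fold higher number from compound 2 to compound 3 (0.35 log units; beyond the scatter), read in reverse for a larger ring on the same nitrogen. A modest move to a lower number is therefore expected in this assay, though a second limit reading remains possible. The expected step is an at least 1.5-fold lower number from compound 3 to compound 4 (0.18 log units; that floor lies within the scatter). The estimate for compound 4 is 26000 nM, with an expected range of 12000 nM to 40000 nM.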

Compound 4, half-maximal inhibitory concentration: 10800 nM
For compound 4 the middle estimate is 2.4-fold (0.38 log units) above the measured one; measured number below the stated range.
By their numbers in this assay, from the lowest: compounds 4, 2 and 1 (each within the scatter of the next, the first and the last beyond it). At a limit, above all of these: compound 3.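

In this assay the two steps to cyclohexyl read a 1.6-fold lower number from compound 2 to compound 4 (0.21 log units; within the scatter) and a 3.2-fold lower number from compound 1 to compound 4 (0.51 log units; beyond the scatter), so a non-aromatic ring on this nitrogen can stand level with phenyl and, unlike phenyl, sit clear of 4-chlorophenyl beyond the scatter. Among the non-aromatic rings, the size of the ring matters at this position, with an at least 3.7-fold lower number from compound 3 to compound 4 (0.56 log units; beyond the scatter). That step is a floor, as the reading for compound 3 is a limit of the assay and not a number: the limit of > 40000 nM in this assay, at which 1 of the 4 values shown sits.

With only cyclopropyl and cyclohexyl as non-aromatic rings, the compounds shown cannot separate ring size from carbon count, and cyclobutyl or cyclopentyl would fill that gap. Also open, as far as these compounds go, is whether an open chain such as n-hexyl, or a cyclohexyl ring carrying an amine or a carboxylic acid, would hold the value of compound 4.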